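A few compounds are considered here, and "the series" means these few. Any claim that something is new, unique, unknown or untested is made for them only; others in the source may bear on it.

In a functional assay on the whole organism with Rattus norvegicus as the target (a lower number here means that less compound is needed, a higher number that more compound is needed for the effect), compound 1 `Nc1ccc2nc(N)sc2c1` reports a limit and not a number (> 10 mg/kg). Compound 3 `CCCc1ccc2nc(N)sc2c1` gives 6 mg/kg and so stands within the scatter of compound 2 `C[Si](C)(C)c1ccc2nc(N)sc2c1` at 5 mg/kg on the same scale. Compound 4 `CC(C)c1ccc2nc(N)sc2c1` has the same atoms as compound 3, joined differently (isopropyl in place of propyl on an aromatic carbon): isopropyl in place of propyl on an aromatic carbon. Measured against the limit, two steps give only floors (an at least 2.0-fold lower number from compound 1 to compound 2 (0.30 log units; that floor lies within the scatter)) and (an at least 1.6-fold lower number from compound 1 to compound 3 (0.22 log units; that floor lies within the scatter)). The closest guide swaps one group without a ring for another on an aromatic carbon and stays within the scatter (a 1.2-fold higher number from compound 2 to compound 3 (0.08 log units; within the scatter)). A step no larger than the scatter is therefore expected in this assay (a 1.1-fold lower number from compound 3 to compound 4 (0.04 log units; within the scatter)). Compound 4 is estimated at 5.5 mg/kg with an expected range of (2.7 mg/kg to 11 mg/kg).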

Compound 4, dose for half-maximal effect: > 10 mg/kg
Compound 4: only a limit was reported (the forecaster's own chance of this, stated with the estimate: 10%); middle value at least 1.8-fold (0.25 log units) away from the limit.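

Putting isopropyl in place of propyl on this aromatic carbon, with the same atoms joined differently, gives an at least 1.6-fold higher number from compound 3 to compound 4 (0.22 log units; that floor lies within the scatter), and the comparison with the silicon-bearing group gives an at least 2.0-fold higher number from compound 2 to compound 4 (0.30 log units; that floor lies within the scatter). The step between compound 1 and compound 4 cannot be read. Joining the same atoms differently at this position is enough to give a limit and not a number, so the true size of both readable steps stays unknown because of that limit: the limit of > 10 mg/kg in this assay, at which 2 of the 4 values shown sit.

On these data alone, whether a butyl chain or a cyclopropyl group here would behave like propyl or like isopropyl stays open.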